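The source may hold more compounds than are shown below. What is called first, only, known or untested is meant among the compounds shown, and "the series" means these compounds.

Measured so far:
- compound 1 `C[C@@H](NC(=O)c1ccc(C#Cc2cc(F)cc(F)c2)cn1)C(C)(C)O`: in a functional assay on HEK293 cells for positive allosteric modulation of metabotropic glutamate receptor 5 (Rattus norvegicus), read by fluorescence and calcium flux (a higher number here means a larger maximal response, a lower number a smaller maximal response), compound 1 gives 61.6%
- compound 2 `C[C@@H](NC(=O)c1ccc(C#CC2CCCC2)cn1)C(C)(C)O`: in this assay compound 2 gives 63.7%

Compound 2 holds the higher of the two numbers, but only by a number 2.1 percentage points higher from compound 1 to compound 2 (within the scatter), so the two compounds cannot be told apart on these values. Compound 3 `C[C@@H](NC(=O)c1ccc(C#Cc2cc(F)ccn2)cn1)C(C)(C)O` is not yet measured. It differs from compound 2 in one place: 4-fluoropyridin-2-yl in place of cyclopentyl on a triple-bonded carbon. Among the measured compounds shown here, the only step measured so far, the swap of 3,5-difluorophenyl for cyclopentyl on the same triple-bonded carbon, was a number 2.1 percentage points higher from compound 1 to compound 2 (within the scatter). That step also exchanges the group on that triple-bonded carbon. It moved the response by almost nothing. For compound 3 the step of a number 1.7 percentage points lower from compound 2 to compound 3 (within the scatter) is therefore expected to stay within the scatter. Compound 3 is estimated to give 62%, with a likely range from 45% to 80%.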

Compound 3, largest response reached (reported as efficacy), in percent of the reference or control that the assay uses: 66.2%
Compound 3: the middle estimate sits 4.2 percentage points below what was measured; measured number inside the range.
By their numbers in this assay, from the lowest: compounds 1, 2 and 3 (each within the scatter of the next).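

At this triple-bonded carbon, 4-fluoropyridin-2-yl brings a six-membered aromatic ring with a hetero atom and a hydrogen-bond acceptor, and in this assay replacing cyclopentyl gives a number 2.5 percentage points higher from compound 2 to compound 3 (within the scatter) while replacing 3,5-difluorophenyl gives a number 4.6 percentage points higher from compound 1 to compound 3 (within the scatter) in the same read-out. The maximal response therefore cannot separate a non-aromatic carbon ring, a difluorinated aromatic ring and a fluorinated pyridine ring at this place, so among these three groups, the exchange leaves no measurable mark. Nothing available explains why these exchanges make so little difference.

On these data alone, all three groups on this carbon are rings, so it remains open whether an open-chain group such as a longer alkyl chain, an amine or a carboxylic acid would keep the response in this range. These compounds also leave open whether any change elsewhere on the shared core would move it beyond the scatter.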